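The source may report more compounds than this note shows. Statements on the series, on what has been measured and on what is new or still open speak of the compounds shown alone.

Working notes on the amide series. Compound 1 `CCn1c(C(=O)N[C@@H](C)C(=O)OC)ccc1C(CC)(CC)c1ccc(OCS(=O)(=O)c2ccccc2)c(C)c1` gives in a functional assay on PC-3 cells (Homo sapiens) for antiproliferative activity, read by MTT assay, with a stated time of 24 h (on this read-out higher numbers stand for weaker inhibition and lower numbers for stronger inhibition), only a limit, > 50000 nM. Compound 2 `CCn1c(C(=O)NCCNC(=O)OC(C)(C)C)ccc1C(CC)(CC)c1ccc(OCS(=O)(=O)c2ccccc2)c(C)c1` likewise gives only a limit, > 50000 nM. Compound 3 `CCn1c(C(=O)N[C@H](CO)CCO)ccc1C(CC)(CC)c1ccc(OCS(=O)(=O)c2ccccc2)c(C)c1` gives 12100 nM. Compound 2 therefore stands at the limit of > 50000 nM in this assay, at which 2 of the 3 values shown sit, together with compound 1. The step that the two limits leave unreadable from compound 1 to compound 2 is uninformative, whereas an at least 4.1-fold lower number from compound 2 to compound 3 (0.61 log units; beyond the scatter) shows that the 3-hydroxy-1-(hydroxymethyl)propyl group does better than the 2-((tert-butoxycarbonyl)amino)ethyl group at this nitrogen. Compound 4 `CCn1c(C(=O)N[C@H](CC(=O)O)C(=O)O)ccc1C(CC)(CC)c1ccc(OCS(=O)(=O)c2ccccc2)c(C)c1` carries the change (1,2-dicarboxyethyl in place of 2-((tert-butoxycarbonyl)amino)ethyl on an amide-type nitrogen). For the measured compounds named here, no measured step covers a 1,2-dicarboxyethyl group, so the only bearing step is the one to compound 3, and its direction is not assumed to transfer; the expected step is a number no higher from compound 2 to compound 4 (the limit leaves the size open). Compound 4 is estimated at 50000 nM, within 15000 nM to 200000 nM, most likely again reported as a limit.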

Compound 4, half-maximal inhibitory concentration: > 50000 nM
Compound 4 gave a limit, no number; the forecaster's own chance of this, stated with the estimate: 70%; the middle value lies on the limit itself.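

In this assay, 1,2-dicarboxyethyl in place of 3-hydroxy-1-(hydroxymethyl)propyl at this amide-type nitrogen gives an at least 4.1-fold higher number from compound 3 to compound 4 (0.61 log units; beyond the scatter), so the gain seen with compound 3 does not carry over to this group. The steps from compound 1 and from compound 2 to compound 4 join two limits and cannot be read. Compound 4 gives a limit, not a number, and joins compound 1 and compound 2 there: the limit of > 50000 nM in this assay, at which 3 of the 4 values shown sit.

Open, on these data alone, is how a 2-hydroxyethyl or 2-aminoethyl group would read at this nitrogen. Also open, as far as these compounds go, is whether a single carboxylic acid on a longer chain would give a number.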